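A Second Hydroxy Group on a Phenylpiperazine Quinone

A few compounds are considered here, and "the series" means these few. Any claim that something is new, unique, unknown or untested is made for them only; others in the source may bear on it.

Compound 1 `Cc1ccccc1N1CCN(C2=CC(=O)c3ccccc3C2=O)CC1` carries a methyl on its outer phenyl ring and gives 5700 nM in a functional assay on DU-145 cells (Homo sapiens) for inhibition, read by MTT assay, with a stated time of 72 h; a higher number here means a weaker inhibitor, a lower number a stronger inhibitor. Going by the values given here, compound 3 `Cc1ccccc1N1CCN(C2=CC(=O)c3cccc(O)c3C2=O)CC1` differs from it by hydroxy in place of hydrogen on an aromatic carbon and gives 2300 nM in this assay, so the step of a 2.5-fold lower number from compound 1 to compound 3 (0.39 log units; beyond the scatter) is the one measured example of this change. Compound 2 `O=C1C(N2CCN(c3ccccc3)CC2)=CC(=O)c2c(O)cccc21` has a different core; the difference between the two cores is not broken down here. In this assay compound 2 gives 15200 nM, the highest of the three numbers. Compound 4 `O=C1C=C(N2CCN(c3ccccc3)CC2)C(=O)c2c(O)ccc(O)c21` has not yet been tested and differs from compound 2 by hydroxy in place of hydrogen on an aromatic carbon. Among the compounds with values here, this is the same kind of change as the one from compound 1 to compound 3, not the same: in compound 4 the entering hydroxy sits para to a hydroxy group, whereas the place in compound 3 has no hydroxy group described around it. A step of about a 2.2-fold lower number from compound 2 to compound 4 (0.34 log units; beyond the scatter) is expected, because a 2.5-fold lower number from compound 1 to compound 3 (0.39 log units; beyond the scatter) lowered the number on a related core. Within the data shown here, compound 4 is therefore estimated at 7000 nM, between 3000 nM and 16000 nM, with wide bounds because only the single step of a 2.5-fold lower number from compound 1 to compound 3 (0.39 log units; beyond the scatter) supports the guess.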

Compound 4, half-maximal inhibitory concentration: 1300 nM
Compound 4: the middle estimate sits 5.4-fold (0.73 log units) above what was measured; measured number outside the range, below it.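

In this assay the hydroxy group lowers the number on the second core as well, with a 12-fold lower number from compound 2 to compound 4 (1.07 log units; beyond the scatter), so the direction of the change carries from one core to the other. The size does not carry over, and a step measured on one core would not have given a reliable figure for the other: the same change on two cores in this assay, a 2.5-fold lower number (0.39 log units; beyond the scatter) from compound 1 to compound 3 and a 12-fold lower number (1.07 log units; beyond the scatter) from compound 2 to compound 4, 4.7-fold (0.67 log units) apart, beyond the scatter of two such steps

These two steps cannot show what sets the size, since the cores differ and the entering hydroxy in compound 4 sits para to a hydroxy group, a setting not described for compound 3, and two examples give no general rule for the series.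

Going by these compounds, it remains open whether a methoxy group or an amine in the same place on the core of compound 2 would also lower the number. The compounds shown also do not tell whether the larger step would persist with a methyl on the outer phenyl ring, as compound 1 and compound 3 carry.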